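The source may report more compounds than this note shows. Statements on the series, on what has been measured and on what is new or still open speak of the compounds shown alone.

In an ADME assay on RAW264.7 cells (Mus musculus) for cytotoxicity, read by MTT assay, with a stated time of 24 h (on this read-out higher numbers stand for weaker inhibition and lower numbers for stronger inhibition), compound 1 `CCCS(=O)(=O)Oc1ccc2c3c(c(=O)oc2c1)CCCCCC3` gives 9200 nM. Compound 2 `Cc1ccc(S(=O)(=O)Oc2ccc3c4c(c(=O)oc3c2)CCCCCC4)cc1` is known only as a limit, > 100000 nM. Compound 3 `O=c1oc2cc(OS(=O)(=O)c3ccc(C(F)(F)F)cc3)ccc2c2c1CCCCCC2` carries trifluoromethyl in place of methyl on an aromatic carbon, para to a large group (trifluoromethyl in place of methyl on an aromatic carbon). Going by the values given here, the only measured step, an at least 10-fold higher number from compound 1 to compound 2 (1.03 log units; beyond the scatter), is large, but it exchanges the whole group on the sulfonyl sulfur and does not touch this position, so it bears on the new change only indirectly. The expected move is a number no higher from compound 2 to compound 3 (the limit leaves the size open), with no shift beyond the scatter in either direction. Compound 3 is estimated at 100000 nM, with an expected range of 30000 nM to 300000 nM.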

Compound 3, half-maximal inhibitory concentration: > 100000 nM
Compound 3 gave a limit, no number; the forecaster's own chance of this, stated with the estimate: 55%; the middle value lies on the limit itself.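

In this assay compound 3, like compound 2, is known only as a limit, so the step between them cannot be read and trifluoromethyl in place of methyl at this position has no measurable size. The result does show that 4-(trifluoromethyl)phenyl on the sulfonyl sulfur, like 4-methylphenyl, stands apart from propyl, with an at least 10-fold higher number from compound 1 to compound 3 (1.03 log units; beyond the scatter). Any difference between the two phenyl groups stays hidden at the limit of the read-out: the limit of > 100000 nM in this assay, at which 2 of the 3 values shown sit.

From the compounds shown here alone, whether an amine or a methoxy group in that place, or a butyl chain in place of propyl on the sulfonyl sulfur, would give a readable number stays open.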